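Aniline Swap on a Hydroxylated Coumarin Core

A few compounds are considered here, and "the series" means these few. Any claim that something is new, unique, unknown or untested is made for them only; others in the source may bear on it.

Compound 1 `COc1ccc(-c2c(Nc3ccc(C)c(O)c3)c3ccccc3oc2=O)cc1` carries a 3-hydroxy-4-methylphenyl group on the ring nitrogen, and in a functional assay on HCT-116 cells (Homo sapiens) for antiproliferative activity, read by MTT assay, with a stated time of 48 h (a lower number here means a stronger inhibitor, a higher number a weaker inhibitor), compound 1 gives 12300 nM. Compound 2 `COc1ccc(-c2c(Nc3ccc(F)cc3)c3ccc(O)cc3oc2=O)cc1` places a hydroxyl on the shared core instead, and in this assay compound 2 gives 66100 nM. Compound 3 `COc1ccc(-c2c(Nc3ccc(C)c(O)c3)c3ccc(O)cc3oc2=O)cc1` combines both features, yet in this assay compound 3 gives "not determined" (no result reported), so it stands without a number. Compound 4 `COc1ccc(-c2c(Nc3cccc(C(F)(F)F)c3)c3ccc(O)cc3oc2=O)cc1` differs from compound 3 by 3-(trifluoromethyl)phenyl in place of 3-hydroxy-4-methylphenyl on a nitrogen on an aromatic ring. With no measured anchor for compound 3, only a modest step is foreseen, likely toward the weak end seen for compound 2 in this assay. Compound 4 is therefore expected to show 40000 nM, within a range from 10000 nM to 160000 nM.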

Compound 4, half-maximal inhibitory concentration: 55900 nM
Compound 4: middle estimate off by 1.4-fold (0.15 log units), on the low side, within the range that was stated.
By their numbers in this assay, from the lowest: compound 1; then compounds 4 and 2 (each within the scatter of the next).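

On the hydroxylated shared core, the group on the nitrogen now has a step that can be read: in this assay, 3-(trifluoromethyl)phenyl in place of 4-fluorophenyl gives a 1.2-fold lower number from compound 2 to compound 4 (0.07 log units; within the scatter) and so no change beyond the scatter. These two fluorine-bearing phenyl groups cannot be told apart at this position. No measurement offered here accounts for this result.

On these data alone, the step from compound 3 to compound 4 cannot be read, so the effect of 3-hydroxy-4-methylphenyl on this core stays open. Also open, as far as these compounds go, is how an amine or a carboxylic acid on this phenyl group would fare.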